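Chloro for acetoxy on two related cores

The source may report more compounds than this note shows. Statements on the series, on what has been measured and on what is new or still open speak of the compounds shown alone.

Measured compounds:
compound 1, `CC(=O)OCCc1c(C)[nH]c(=O)[nH]c1=O`, > 100000 nM
compound 2, `COc1nc(C)c(CCOC(C)=O)c(OC)n1`, "not determined" (no result reported)
compound 3, `Cc1[nH]c(=O)[nH]c(=O)c1CCCl`, > 100000 nM

In a functional assay on MOLT-4 cells (Homo sapiens) for antiproliferative activity, read by MTT assay, with a stated time of 24 h (on this read-out higher numbers stand for weaker inhibition and lower numbers for stronger inhibition), compound 1 gives > 100000 nM, which is a limit of the assay and not a number. In this assay compound 3 likewise gives > 100000 nM, again a limit. For compound 2 this assay reports "not determined" (no result reported).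

The change from compound 1 to compound 3 is chloro in place of acetoxy on a saturated chain carbon, two bonds along the chain from an aromatic carbon. The step it made, a step that the two limits leave unreadable from compound 1 to compound 3, cannot be read because the limit of > 100000 nM in this assay, at which 2 of the 3 values shown sit, holds both ends of it. How the core of compound 2 differs from the core of compound 1 is not broken down here.

Compound 4, `COc1nc(C)c(CCCl)c(OC)n1`, has not yet been measured in this assay. It stands to compound 2 as compound 3 stands to compound 1: the change is chloro in place of acetoxy on a saturated chain carbon, two bonds along the chain from an aromatic carbon, and the place is the same in both pairs, so it is the same change. Among the compounds with values here, no size can be carried over from the earlier pair, since the only measured instance of the change left both compounds at a limit. For compound 4 the expected result in this assay is therefore 100000 nM, most likely reported as a limit rather than a number. As an estimate, the value of compound 4 should fall between 30000 nM and 300000 nM, and this rests only on the fact that compound 1 and compound 3 both sit at the limit, with no value for compound 2 to anchor the second core.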

Compound 4, half-maximal inhibitory concentration: > 100000 nM
Compound 4 was reported as a limit; the forecaster's own chance of this, stated with the estimate: 85%; the middle value sits exactly at the limit.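

In this assay compound 4 gives > 100000 nM, which is a limit and not a number. No new step can be read from compound 2 to compound 4, and the result joins the others at the same ceiling: the limit of > 100000 nM in this assay, at which 3 of the 4 values shown sit.

The compounds shown leave open whether chloro in place of acetoxy changes antiproliferative activity on either core, and whether any member of the series reaches a readable value.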